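Replacing the amide of compound 2 with a piperidinylmethyl arm

The compounds below may be only part of what the source reports. "The series", "measured", "known", "first", "only" and "open" are said of these compounds alone.

Compound 1 `N#CC1=C(NCC(=O)O)N(c2ccccc2)C(=O)N2CCCCC(N3CCCC3)C12` gives 89.2% in a functional assay on the whole organism (strain albino) for inhibition, with Rattus norvegicus as the target, read by paw edema, with stated times of 1 h and 3 h, at a dose of 20 mmol/kg by the intraperitoneal route; a higher number here means a stronger effect of the compound at the dose given, a lower number a weaker effect. Compound 2 `N#CC1=C(NCC(=O)N2CCCC2)N(c2ccccc2)C(=O)N2CCCCC(N3CCCC3)C12` gives 56% in this assay, the lower of the two numbers, with the step of a number 33.2 percentage points lower from compound 1 to compound 2 (beyond the scatter). Compound 3 `N#CC1=C(NCN2CCCCC2)N(c2ccccc2)C(=O)N2CCCCC(N3CCCC3)C12` differs from compound 2 as piperidin-1-yl in place of (pyrrolidin-1-yl)carbonyl on a saturated chain carbon bound to an amine nitrogen. Among the measured compounds shown here, no measured step covers this change; the only known step ends at compound 2 and does not carry the carbonyl away. The account therefore expects for compound 3 no step beyond the scatter, a number 6 percentage points lower from compound 2 to compound 3 (within the scatter), and estimates for compound 3 a value of 50%, within a range of 25% to 75%.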

Compound 3, a percentage reported as inhibition, in the whole organism at one dose (the size of the read-out at that dose, not a potency): 42.1%
Compound 3: the middle estimate sits 7.9 percentage points above what was measured, and the stated range covers the measured number.
By their numbers in this assay, from the lowest: compound 3; then compound 2; then compound 1.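

Exchanging (pyrrolidin-1-yl)carbonyl for piperidin-1-yl on this saturated chain carbon bound to an amine nitrogen gives a number 13.9 percentage points lower from compound 2 to compound 3 (beyond the scatter) in this assay and so lowers the effect further. Exchanging carboxy for the same group gives a number 47.1 percentage points lower from compound 1 to compound 3 (beyond the scatter) and leaves compound 3 with the lowest number of the three. Nothing measured here explains these steps.

From the compounds shown here alone, whether a morpholine or a dimethylamine in place of piperidin-1-yl would give a higher number remains open. So does the effect of a carboxylic acid on a longer chain at this position.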